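The source may hold more compounds than are shown below. What is called first, only, known or untested is meant among the compounds shown, and "the series" means these compounds.

- Compound 1 `OC(c1ccc(Cl)cc1)(c1cccnc1)c1ccccc1F`: > 100000 nM, a limit of the assay and not a number
- Compound 2 `OC(c1ccc(Cl)cc1)(c1cccnc1)c1cccs1`: 67700 nM

For the measured compounds named here, in an ADME assay on L6 cells (Rattus norvegicus) for cytotoxicity, read by resazurin assay, with a stated time of 72 h (a higher number here means a weaker inhibitor, a lower number a stronger inhibitor), compound 2 gives 67700 nM, the only actual number available so far. Compound 1 sits at > 100000 nM, which is a limit. the limit of > 100000 nM in this assay, at which 1 of the 2 values shown sits.

Compound 3 `OC(c1ccc(Cl)cc1)(c1cccnc1)c1cnc(Cl)s1` differs from compound 2 in one group: 2-chloro-1,3-thiazol-5-yl in place of thiophen-2-yl on a saturated chain carbon bound to two aromatic carbons and an oxygen on a saturated carbon. This places 2-chloro-1,3-thiazol-5-yl in place of thiophen-2-yl on a saturated chain carbon bound to two aromatic carbons and an oxygen on a saturated carbon.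

Going by the values given here, only one measured step bears on this change, as it involves a swap on that same carbon: an at least 1.4-fold lower number from compound 1 to compound 2 (0.16 log units; that floor lies within the scatter). That step is only a floor, and it sets neither a size nor a direction for the new exchange. On the evidence of compound 2 and this single step, no change beyond the scatter is expected in this assay. The expected step is a 1.1-fold lower number from compound 2 to compound 3 (0.05 log units; within the scatter). For compound 3 the estimated value is 60000 nM. The expected range for compound 3 runs from 20000 nM to 100000 nM.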

Compound 3, half-maximal inhibitory concentration: > 100000 nM
Compound 3 gave a limit, no number; the forecaster's own chance of this, stated with the estimate: 25%; middle value at least 1.6-fold (0.22 log units) away from the limit.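

In this assay, the exchange of thiophen-2-yl for 2-chloro-1,3-thiazol-5-yl on this carbon gives an at least 1.4-fold higher number from compound 2 to compound 3 (0.16 log units; that floor lies within the scatter), a floor and not a measured size, so it gives a direction but shows no change that can be told from the scatter. The step between compound 1 and compound 3 cannot be read, since both values are limits, and so the 2-fluorophenyl and 2-chloro-1,3-thiazol-5-yl groups cannot be ordered against each other. What compound 3 adds is a second group on this carbon that ends at the limit, which leaves thiophen-2-yl as the only group here with an actual number: the limit of > 100000 nM in this assay, at which 2 of the 3 values shown sit.

On these data alone, how far the true values of compound 1 and compound 3 lie past that limit stays open, and with it whether either step with compound 2 exceeds the scatter. Also open, as far as these compounds go, is what an unsubstituted phenyl ring, an amine or a carboxylic acid on this same carbon would give in this assay.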